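The source may report more compounds than this note shows. Statements on the series, on what has been measured and on what is new or still open speak of the compounds shown alone.

Measured in a physicochemical assay for lipophilicity, using the shake flask method; a lower number here means a more polar compound, a higher number a more lipophilic compound:
- Compound 1 `C[C@H](Oc1ccc2ncc(/C=C/C(=O)O)c(C3CC3)c2c1)c1c(Cl)cccc1Cl`: 3.7
- Compound 2 `C[C@H](Oc1ccc2ncc(/C=C/C(=O)NS(C)(=O)=O)c(C3CC3)c2c1)c1c(Cl)cccc1Cl`: 2.9

Compound 1 stands higher of the two, at 3.7. Compound 3 `C[C@H](Oc1ccc2ncc(/C=C/C(=O)O)c(C3CC3)c2c1)c1c(Cl)ccc(N)c1Cl` carries one change from compound 1: amino in place of hydrogen on an aromatic carbon, with amino in place of hydrogen on an aromatic carbon. Within the data shown here, no measured step touches that spot. The only one, a number 0.80 log units lower from compound 1 to compound 2 (beyond the scatter), puts methanesulfonamido in place of hydroxy on a carbonyl carbon, so it is a rough guide to size alone. A similarly modest move to a lower number is expected, and the estimated step is a number 0.60 log units lower from compound 1 to compound 3 (beyond the scatter). For compound 3 the estimate is 3.1, with an expected range of 2.6 to 3.5.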

Compound 3, distribution coefficient: 2.8
For compound 3 the middle estimate is 0.30 log units above the measured one; low and high end bracket the measured number.
By their numbers in this assay, from the lowest: compounds 3 and 2 (each within the scatter of the next); then compound 1.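

In this assay, amino in place of hydrogen on an aromatic carbon, ortho to a chloro group and para to a chloro group, gives a number 0.90 log units lower from compound 1 to compound 3 (beyond the scatter). Among these compounds, the earlier step changed only the group on the carbonyl carbon, so this is the first sign that the ring carrying the chloro groups can also shift this number, here through one added nitrogen atom. Nothing measured here gives a reason for the shift.

Going by these compounds, whether methylamino or acetamido at this spot would shift the number as far remains open. So does whether amino would give a similar step on compound 2.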